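Indole attachment on the anilino nitrogen: compound 3 to compound 4

A few compounds are considered here, and "the series" means these few. Any claim that something is new, unique, unknown or untested is made for them only; others in the source may bear on it.

Compound 1 `Cn1c(=O)c(S(=O)(=O)c2ccc(Cl)cc2Cl)cc2cnc(Nc3ccc4[nH]ccc4c3)nc21` in a functional assay on K562 cells (Homo sapiens) for inhibition, read by trypan blue exclusion, with a stated time of 72 h; a higher number here means a weaker inhibitor, a lower number a stronger inhibitor: 1000 nM
Compound 2 `COc1ccc(Nc2ncc3cc(S(=O)(=O)c4ccc(C)cc4)c(=O)n(C)c3n2)cc1`: 75000 nM
Compound 3 `Cc1ccc(S(=O)(=O)c2cc3cnc(Nc4ccc5cc[nH]c5c4)nc3n(C)c2=O)cc1`: 15000 nM

Compound 3, at 15000 nM, holds the middle of the three numbers, with compound 2 higher and compound 1 lower, both gaps beyond the scatter. The change to compound 4 `Cc1ccc(S(=O)(=O)c2cc3cnc(Nc4ccc5[nH]ccc5c4)nc3n(C)c2=O)cc1` is 1H-indol-5-yl in place of 1H-indol-6-yl on a nitrogen on an aromatic ring: the same atoms, joined differently, with 1H-indol-5-yl in place of 1H-indol-6-yl on a nitrogen on an aromatic ring.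

Within the data shown here, one measured step touches this substituent: a 5.0-fold lower number from compound 2 to compound 3 (0.70 log units; beyond the scatter), with 1H-indol-6-yl in place of 4-methoxyphenyl. It shows that this group can shift this assay, but it does not test the indole attachment. Compound 1, which carries 1H-indol-5-yl, gives 1000 nM, yet it also differs from compound 3 elsewhere, so the value is only a weak pointer. A modest move to a lower number is expected, and a result within the scatter would not be surprising. The expected change is a 2.5-fold lower number from compound 3 to compound 4 (0.40 log units; beyond the scatter). For compound 4 the estimated value is 6000 nM, with an expected range of 1500 nM to 20000 nM.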

Compound 4, half-maximal inhibitory concentration: 750 nM
For compound 4 the middle estimate is 8.0-fold (0.90 log units) above the measured one; measured number outside the range, below it.
By their numbers in this assay, from the lowest: compounds 4 and 1 (each within the scatter of the next); then compound 3; then compound 2.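

In this assay, the attachment point of the indole on a nitrogen on an aromatic ring matters on its own: with the same atoms joined differently, the change gives a 20-fold lower number from compound 3 to compound 4 (1.30 log units; beyond the scatter), larger than a 5.0-fold lower number from compound 2 to compound 3 (0.70 log units; beyond the scatter), and 1H-indol-5-yl in place of 4-methoxyphenyl gives a 100-fold lower number from compound 2 to compound 4 (2.00 log units; beyond the scatter) overall. With 1H-indol-5-yl held constant, 4-methylphenyl in place of 2,4-dichlorophenyl on a sulfonyl sulfur gives a 1.3-fold lower number from compound 1 to compound 4 (0.12 log units; within the scatter), so these two sulfonyl groups are not told apart in this assay. Nothing available explains the size of the shift between the two indole attachments.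

Still open, as far as these compounds go, is whether an indazole, or a 1-methylindol-5-yl group with a methyl on the indole nitrogen, would keep the low number of compound 4. Also open, from the compounds shown here alone, is how a piperazine on the sulfonyl aryl ring would read.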